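The source may report more compounds than this note shows. Statements on the series, on what has been measured and on what is new or still open speak of the compounds shown alone.

Of the compounds shown here, three have been measured in an assay on cells for displacement of a labelled ligand from Glucagon receptor (Homo sapiens), in the presence of a further agent that is not named here; a higher number here means a weaker inhibitor, a lower number a stronger inhibitor. Compound 1 `O=C(O)CCNC(=O)c1ccc(C(Oc2ccc(-n3cc(C(F)(F)F)cn3)cc2)C2CCCC2)cc1` gives 420 nM, the highest number of the three. Compound 2 `CCCC(Nc1cc(C)c(-n2cc(C(F)(F)F)cn2)c(C)c1)c1ccc(C(=O)NCCC(=O)O)cc1` gives 12 nM, and compound 3 `CCCC(Nc1cnc(-n2cc(C(F)(F)F)cn2)nc1)c1ccc(C(=O)NCCC(=O)O)cc1` gives 100 nM; both are stronger inhibitors than compound 1, and both gaps lie beyond the usual scatter. Compound 4 `O=C(O)CCNC(=O)c1ccc(C(Oc2ccc(-n3cc(C(F)(F)F)cn3)cc2)C2CCC2)cc1` has not yet been measured. It differs from compound 1 in one place: cyclobutyl in place of cyclopentyl on a saturated chain carbon bound to an aromatic carbon and an oxygen on an aromatic ring. For the measured compounds named here, no measured pair shows this change, so the data give no direct guide to its effect. A small alteration in the size of a saturated ring is expected to move the number little, and the step expected in this assay is a 1.4-fold higher number from compound 1 to compound 4 (0.15 log units; within the scatter), within or only slightly beyond the scatter, toward a weaker inhibitor if anything. Compound 4 is therefore estimated at 600 nM, with a range from 200 nM to 1800 nM.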

Compound 4, inhibition constant: 700 nM
Estimate against measurement, compound 4: 1.2-fold (0.07 log units) below; measured number inside the range.
By their numbers in this assay, from the lowest: compound 2; then compound 3; then compounds 1 and 4 (each within the scatter of the next).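

Placing cyclobutyl in place of cyclopentyl on a saturated chain carbon bound to an aromatic carbon and an oxygen on an aromatic ring gives a 1.7-fold higher number from compound 1 to compound 4 (0.22 log units; within the scatter) in this assay. This first one-place comparison shows that, at this position, the two ring sizes cannot be told apart in this measurement. No available evidence bears on this result. The compounds shown leave open whether a larger ring such as cyclohexyl, or an open chain such as isopropyl, on this carbon would shift the number beyond the scatter.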